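The compounds below may be only part of what the source reports. "The series", "measured", "known", "first", "only" and "open" are said of these compounds alone.

Compound 1 (`N#CC12CC(CN([C@H](CCC(F)(F)F)C(N)=O)S(=O)(=O)c3ccc(Cl)cc3)(C1)C2`), compound 2 (`N#C[C@H]1C[C@H](CN([C@H](CCC(F)(F)F)C(N)=O)S(=O)(=O)c2ccc(Cl)cc2)C1`) and compound 3 (`C[C@]1(C#N)C[C@@H](CN([C@H](CCC(F)(F)F)C(N)=O)S(=O)(=O)c2ccc(Cl)cc2)C1`) share one core and differ only in the group on a saturated chain carbon bound to a sulfonamide nitrogen. In an ADME assay on MDCKII-LE cells (Canis lupus familiaris) for permeability (a higher number here means that the compound crosses the layer faster, a lower number that the compound crosses the layer more slowly), compound 1 gives 30.2 10^-6 cm/s, compound 2 gives 24.9 10^-6 cm/s and compound 3 gives 25.7 10^-6 cm/s, so compound 3 stands level with the other two within the scatter.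

Compound 4 (`NC(=O)[C@@H](CCC(F)(F)F)N(CC1(c2ncon2)CC1)S(=O)(=O)c1ccc(Cl)cc1`) carries 1-(1,2,4-oxadiazol-3-yl)cyclopropyl in place of the 3-cyano-3-methylcyclobutyl of compound 3: 1-(1,2,4-oxadiazol-3-yl)cyclopropyl in place of 3-cyano-3-methylcyclobutyl on a saturated chain carbon bound to a sulfonamide nitrogen.

Within the data shown here, three measured steps bear on this change. They are a 1.2-fold lower number from compound 1 to compound 2 (0.08 log units; within the scatter), a 1.2-fold lower number from compound 1 to compound 3 (0.07 log units; within the scatter) and a 1.0-fold higher number from compound 2 to compound 3 (0.01 log units; within the scatter), and all are small. Among the measured compounds shown here, none of the measured compounds carries the entering group, however, so these steps are only a loose guide and the range must stay wide.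

On that basis, no shift beyond the scatter is expected in this assay, and the estimated step is a 1.2-fold lower number from compound 3 to compound 4 (0.07 log units; within the scatter). For compound 4 the expected value is 22 10^-6 cm/s, with an estimated range from 11 10^-6 cm/s to 35 10^-6 cm/s.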

Compound 4, apparent permeability: 16.4 10^-6 cm/s
Compound 4: middle estimate off by 1.3-fold (0.13 log units), on the high side; measured number inside the range.
By their numbers in this assay, from the lowest: compounds 4, 2, 3 and 1 (each within the scatter of the next).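

Replacing the groups of compound 1, compound 2 and compound 3 with 1-(1,2,4-oxadiazol-3-yl)cyclopropyl gives, in this assay, a 1.6-fold lower number from compound 3 to compound 4 (0.20 log units; within the scatter), a 1.5-fold lower number from compound 2 to compound 4 (0.18 log units; within the scatter) and a 1.8-fold lower number from compound 1 to compound 4 (0.27 log units; within the scatter). The position on a saturated chain carbon bound to a sulfonamide nitrogen therefore accepts a group with no nitrile, with a three-membered ring and a five-membered aromatic ring, with no shift beyond the scatter. No measurement shown here offers an explanation for the size of these steps.

Compound 4 changes the three-membered ring and the five-membered aromatic ring together, so the part played by each remains unresolved. As far as these compounds go, it also remains open whether a carboxylic acid or an amine at this position would give a step beyond the scatter.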